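Removing the aromatic methyl: the expected whole-organism reading

The compounds below may be only part of what the source reports. "The series", "measured", "known", "first", "only" and "open" are said of these compounds alone.

Compound 1 `C/C(C(=O)NC1CC1)=C(\C)c1ccc(Br)cc1` gives 300 mg/kg in a toxicity assay on the whole organism (strain Icem-CET (SPF Caw)) for cytotoxicity, with Mus musculus as the target; on this read-out higher numbers stand for an effect only at larger amounts of compound and lower numbers for an effect already at smaller amounts.
Compound 2 `C/C(C(=O)NC1CC1)=C(\C)c1ccc(C)cc1` gives 280 mg/kg in this assay.
Compound 3 `C=CCNC(=O)/C(C)=C(/C)c1ccc(C)cc1` gives 280 mg/kg in this assay.

Compound 2 stands level with compound 3 at the digits given, the two of them together the lowest of the three numbers; compound 1 is its furthest neighbour, and even that gap lies within the scatter, so all three readings are treated as one level.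

Compound 4 `C/C(C(=O)NC1CC1)=C(\C)c1ccccc1` is the next member and has not yet been measured. It differs from compound 2 in one place: hydrogen in place of methyl on an aromatic carbon.

Going by the values given here, two measured steps bear on this change. The step on the same aromatic carbon, a 1.1-fold lower number from compound 1 to compound 2 (0.03 log units; within the scatter), exchanged one substituent for another there without moving the reading. The step on the amide nitrogen, no change at the digits printed from compound 2 to compound 3 (within the scatter), shows the same flatness at the other end of the molecule. Neither step moved the number beyond the scatter, so no step beyond the scatter is expected for compound 4 either; the estimated change is no change at the digits printed from compound 2 to compound 4 (within the scatter).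

Compound 4 is therefore expected to give about 280 mg/kg in this assay, with a range from 150 mg/kg to 520 mg/kg.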

Compound 4, dose for half-maximal effect: 400 mg/kg
Beside the measured number, compound 4's estimate is 1.4-fold (0.15 log units) below it; measured number inside the range.
By their numbers in this assay, from the lowest: compounds 2, 3, 1 and 4 (each within the scatter of the next).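

The methyl on this aromatic carbon, para to a large group, can give way to hydrogen with the reading in this assay staying within the scatter: the change gives a 1.4-fold higher number from compound 2 to compound 4 (0.15 log units; within the scatter) and hydrogen in place of bromo gives a 1.3-fold higher number from compound 1 to compound 4 (0.12 log units; within the scatter) on the same carbon. The earlier compounds shown here compared only two substituents at this position, whereas these steps show that the reading does not depend on a heavy atom being there at all, so bromo, methyl and hydrogen cannot be told apart here. Nothing available accounts for this flatness or says what lies behind the small gaps between the three.

Going by these compounds, what stays open is whether any group on this aromatic carbon can move the number beyond the scatter, for instance an amine, a carboxylic acid, a methoxy group or a longer chain, since the three substituents compared so far span only a narrow set. On these data alone, it is equally open whether hydrogen in place of methyl would read the same with allyl rather than cyclopropyl on the amide nitrogen.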